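This account rests on a few compounds, and the source may have more. Where it says the series, first, only, none or still open, it means among the compounds named here.

Measured compounds in the series:
compound 1, `CC1CCC(=NNc2ccccc2)c2ncc(C(=O)O)c(=O)n21`: in a functional assay on the whole organism with Rattus norvegicus as the target (a higher number here means that more compound is needed for the effect, a lower number that less compound is needed), compound 1 gives 1.2 umol/kg.
compound 2, `Cc1cccc(NN=C2CCC(C)n3c2ncc(C(=O)O)c3=O)c1C`: in this assay compound 2 gives only a limit of the assay, > 100 umol/kg.
compound 3, `Cc1cc(C)cc(NN=C2CCC(C)n3c2ncc(C(=O)O)c3=O)c1`: in this assay compound 3 gives only a limit of the assay, > 320 umol/kg.

Compound 2 thus stands at a limit and not at a number; one further value shown is likewise a limit (the limit of > 100 umol/kg in this assay, at which 1 of the 3 values shown sits, (the limit of > 320 umol/kg in this assay, at which 1 of the 3 values shown sits)).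

The next compound is compound 4, `CC1CCC(=NNc2ccc(Br)cc2Cl)c2ncc(C(=O)O)c(=O)n21`. The change from compound 2 is 4-bromo-2-chlorophenyl in place of 2,3-dimethylphenyl on an amine nitrogen.

Going by the values given here, two measured steps bear on substituted phenyl groups at this nitrogen: an at least 83-fold higher number from compound 1 to compound 2 (1.92 log units; beyond the scatter) and an at least 260-fold higher number from compound 1 to compound 3 (2.42 log units; beyond the scatter), both large and beyond the scatter, both moving away from the unsubstituted phenyl of compound 1. The step that the two limits leave unreadable from compound 2 to compound 3 is not readable from two limits. Among the compounds with values here, no measured step exchanges one disubstituted phenyl for another with a readable size, and no halogen on this phenyl has been measured. Compound 4 keeps two substituents on the phenyl, so the expected step is an at least 2.5-fold lower number from compound 2 to compound 4 (0.39 log units; beyond the scatter). With compound 2 at a limit, this expectation is loosely held. Compound 4 is therefore estimated at 40 umol/kg, with a range from 4 umol/kg to 400 umol/kg.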

Compound 4, dose for 50% inhibition: > 100 umol/kg
Compound 4 was reported as a limit; the forecaster's own chance of this, stated with the estimate: 40%; middle value at least 2.5-fold (0.39 log units) from the limit.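

In this assay compound 4 gives only a limit of the assay, > 100 umol/kg. Against the unsubstituted phenyl, the change to 4-bromo-2-chlorophenyl on the amine nitrogen gives an at least 83-fold higher number from compound 1 to compound 4 (1.92 log units; beyond the scatter), so a halogen-bearing phenyl now joins 2,3-dimethylphenyl and 3,5-dimethylphenyl, and none of the three substituted phenyls shown stays near phenyl. Compound 4 and compound 2 share the same limit: the limit of > 100 umol/kg in this assay, at which 2 of the 4 values shown sit.

The steps among compound 2, compound 3 and compound 4 cannot be read, and no order among these three substituted phenyls can be drawn from them. Open, on these data alone, is whether a phenyl carrying a single fluorine or a single methyl, or a pyridyl in place of phenyl on the amine nitrogen, would stay close to compound 1 at 1.2 umol/kg.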